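The compounds below may be only part of what the source reports. "The series", "measured", "known", "first", "only" and "open" are said of these compounds alone.

Measured so far, in a functional assay on the whole organism (strain Swiss albino) for inhibition, with Mus musculus as the target, in the writhing test, with a stated time of 30 min, at a dose of 10 mg/kg by the oral route; a higher number here means a stronger effect of the compound at the dose given, a lower number a weaker effect:
compound 1, `Cc1c(C=O)cc(-c2ccc(S(C)(=O)=O)cc2)n1-c1cccc(F)c1`, gives 39%
compound 2, `Cc1c(/C=N\O)cc(-c2ccc(S(C)(=O)=O)cc2)n1-c1cccc(F)c1`, gives 32%
compound 3, `Cc1c(/C=N\O)cc(-c2ccc(S(C)(=O)=O)cc2)n1-c1ccc(F)c(F)c1`, gives 19%

Among these three numbers compound 2 holds the second highest place. Its nearest neighbour is compound 1, and the step of a number 7 percentage points lower from compound 1 to compound 2 (within the scatter) lies within the usual scatter of the test, so the two cannot be ranked against each other. Compound 3 is further away, and the step of a number 13 percentage points lower from compound 2 to compound 3 (beyond the scatter) falls beyond the scatter, though it counts as modest.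

The next compound, compound 4, `Cc1c(C#N)cc(-c2ccc(S(C)(=O)=O)cc2)n1-c1cccc(F)c1`, has not yet been measured in this assay. It comes from compound 2 by one change: a group of 2 heavy atoms (1 carbon, 1 nitrogen; no ring) in place of a group of 3 heavy atoms (1 carbon, 1 nitrogen, 1 oxygen; no ring), on an aromatic carbon. The cyano group takes the place of the group of 3 heavy atoms on the same aromatic carbon of the five-membered ring.

Going by the values given here, of the measured steps, only the one from compound 1 to compound 2 touches that same carbon: there the group of 2 heavy atoms became the group of 3 heavy atoms, and the step of a number 7 percentage points lower from compound 1 to compound 2 (within the scatter) stayed within the scatter. The step from compound 2 to compound 3 changes a different part of the molecule and says nothing about this position. Because a number 7 percentage points lower from compound 1 to compound 2 (within the scatter) was so small, no step beyond the scatter is expected from compound 2 to compound 4, in either direction. Compound 4 is therefore expected to give about 35%, within a range of 20% to 50%, which amounts to an expected step of a number 3 percentage points higher from compound 2 to compound 4 (within the scatter).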

Compound 4, a percentage reported as inhibition, in the whole organism at one dose (the size of the read-out at that dose, not a potency): 28%
Compound 4: middle estimate off by 7 percentage points, on the high side; measured number inside the range.
By their numbers in this assay, from the lowest: compounds 3, 4, 2 and 1 (each within the scatter of the next, the first and the last beyond it).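

Swapping the group on this aromatic carbon for cyano removes the only hydrogen-bond donor in that group (1 in the group that leaves, 0 in cyano), yet in this assay the result is only a number 4 percentage points lower from compound 2 to compound 4 (within the scatter), so this donor count shows no readable link to the read-out in this pair. Going by these compounds alone, the comparison with the formyl compound adds something new, as a number 11 percentage points lower from compound 1 to compound 4 (beyond the scatter) is the first step at this position to pass beyond the scatter, although it is modest, and it shows that the position is not wholly indifferent to what it carries. Compound 2 sits within the scatter of both compound 1 and compound 4, so the three groups do not form a clear ranking, and no measurement here accounts for the gap between formyl and cyano.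

From the compounds shown here alone, it remains open what an amine, a carboxylic acid or a longer chain on this same aromatic carbon would give in this test at this single dose. Also open, going by these compounds, is how cyano would behave alongside the other aryl group carried by compound 3, since a step at one position need not carry over to another core.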